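A few compounds are considered here, and "the series" means these few. Any claim that something is new, unique, unknown or untested is made for them only; others in the source may bear on it.

In a functional assay on the whole organism (Tail, strain ICR) with Mus musculus as the target, in the tail flick test, with a stated time of 60 min, at a dose of 25 umol/kg by the oral route (a higher number here means a stronger effect of the compound at the dose given, a lower number a weaker effect), compound 2 `O=C(CN(c1nc(Cl)nc2[nH]cnc12)C1CC1)N[C@@H](CO)C(=O)O` gives 39.8%, the largest of the three numbers, though its gaps to compound 3 `O=C(OCc1ccccc1)[C@@H]1CCCN1C(=O)CN(c1ncnc2c1ncn2C1CCCCO1)C1CC1` at 36.7% and to compound 1 `O=C(CN(c1nc(Cl)nc2[nH]cnc12)C1CC1)N[C@@H](CO)C(=O)OCc1ccccc1` at 34.2% both lie within the scatter. Compound 4 `CSCC[C@H](NC(=O)CN(c1nc(Cl)nc2[nH]cnc12)C1CC1)C(=O)O` differs from compound 2 by (methylsulfanyl)methyl in place of hydroxy on a saturated chain carbon, two bonds along the chain from an amide-type nitrogen and a carbonyl carbon. Within the data shown here, the only measured step, a number 5.6 percentage points higher from compound 1 to compound 2 (within the scatter), concerned a different part of the molecule and stayed within the scatter, so no measured step speaks directly to the present change. With nothing pointing either way, the step of a number 1.8 percentage points lower from compound 2 to compound 4 (within the scatter) is expected to stay within the scatter. Compound 4 is therefore estimated at 38%, with a range from 25% to 51%.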

Compound 4, a percentage reported as activity, at one dose (the size of the read-out at that dose, not a potency): 22.8%
The estimate for compound 4 lay 15.2 percentage points above the measured number, outside the stated range (below it).
By their numbers in this assay, from the lowest: compound 4; then compounds 1, 3 and 2 (each within the scatter of the next).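

This is the first change among these compounds to go beyond the scatter: a number 17 percentage points lower from compound 2 to compound 4 (beyond the scatter) in this assay shows that the group on this saturated chain carbon can matter at the dose given. The earlier step, hydrogen in place of benzyl on an oxygen next to a carbonyl group, did not show this. Nothing available explains the drop.

On these data alone, it remains open whether the drop follows from losing the hydroxy, from the longer group or from the sulfur. A plain methyl, an amine or a longer carbon chain at this position could help separate these possibilities.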